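Replacing fluoro with methoxy on a bromophenyl ring

The source may hold more compounds than are shown below. What is called first, only, known or untested is meant among the compounds shown, and "the series" means these compounds.

In a functional assay on PC-3 cells (Homo sapiens) for inhibition, read by MTT assay, with a stated time of 48 h, tested at 10 uM (a lower number here means less inhibition of growth, a higher number more inhibition of growth at the concentration tested), compound 1 `Cc1cc(=O)c2c(O)c(CN3CCN(C(=O)OC(C)(C)C)CC3)c(O)c([C@H]3CCN(C)C[C@H]3O)c2o1` gives 1%, compound 2 `Cc1oc2c([C@H]3CCN(C)C[C@H]3O)c(O)cc(O)c2c(=O)c1C(O)c1cccc(Cl)c1` gives 31%, and compound 3 `Cc1oc2c([C@H]3CCN(C)C[C@H]3O)c(O)cc(O)c2c(=O)c1C(O)c1ccc(F)c(Br)c1` gives 72%, the highest of the three. Compound 4 `COc1ccc(C(O)c2c(C)oc3c([C@H]4CCN(C)C[C@H]4O)c(O)cc(O)c3c2=O)cc1Br` has methoxy in place of fluoro on an aromatic carbon, ortho to a bromo group and para to a large group: methoxy in place of fluoro on an aromatic carbon. Going by the values given here, only one measured step bears on this ring, a number 41 percentage points higher from compound 2 to compound 3 (beyond the scatter), and it is large, with 3-bromo-4-fluorophenyl in place of 3-chlorophenyl. Among the compounds with values here, no measured compound carries methoxy. Some of that gain is therefore expected to be lost, giving an estimated moderate drop in this assay, a number 17 percentage points lower from compound 3 to compound 4 (beyond the scatter). For compound 4 the estimated value is 55%, within an expected range of 30% to 78%.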

Compound 4, percent growth inhibition at one concentration: 0%
For compound 4 the middle estimate is 55 percentage points above the measured one; the measured number lies below the stated range.
By their numbers in this assay, from the lowest: compounds 4 and 1 (each within the scatter of the next); then compound 2; then compound 3.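

Methoxy in place of fluoro on this ring carbon gives a number 72 percentage points lower from compound 3 to compound 4 (beyond the scatter) in this assay, so the bromo group alone does not secure the high number, and the group on this one carbon matters greatly. The 3-bromo-4-methoxyphenyl ring also compares poorly with the plain 3-chlorophenyl ring, giving a number 31 percentage points lower from compound 2 to compound 4 (beyond the scatter). Nothing available here explains this loss.

The compounds shown leave open whether the loss is specific to methoxy or would also appear with hydroxy, an amine or a longer ether such as ethoxy on this carbon.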